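Swapping Fluoro for Methoxy on a Shared Core

The source may report more compounds than this note shows. Statements on the series, on what has been measured and on what is new or still open speak of the compounds shown alone.

Compound 1 `CC(=O)c1cc(-c2ccc(F)cc2)cc2cc(-c3ccccc3)[nH]c12` and compound 2 `COc1ccc(-c2cc(C(C)=O)c3[nH]c(-c4ccccc4)cc3c2)cc1` share a core and differ in one place: methoxy in place of fluoro on an aromatic carbon. In a functional assay on HeLa cells (Homo sapiens) for cytotoxicity, read by MTT assay, with a stated time of 2 days, tested at 0.1 uM (on this read-out lower numbers stand for a stronger effect and higher numbers for a weaker effect at the one concentration tested), compound 1 gives 90.3%, and compound 2 gives 87.9%; the step between them is a number 2.4 percentage points lower from compound 1 to compound 2 (within the scatter). Compound 3 `CC(=O)c1cc(/C=C/c2ccc(F)cc2)cc2cc(-c3ccc(F)cc3)[nH]c12` is built on a different core; the difference between the two cores is not broken down here. In this assay compound 3 gives 72.6%, the lowest of the three numbers and beyond the scatter from both of the others. Compound 4 `COc1ccc(-c2cc3cc(/C=C/c4ccc(F)cc4)cc(C(C)=O)c3[nH]2)cc1` has not yet been measured. It differs from compound 3 by methoxy in place of fluoro on an aromatic carbon, the same change as between compound 1 and compound 2, at the same place on the ring. Because the earlier instance of this change gave a number 2.4 percentage points lower from compound 1 to compound 2 (within the scatter), a step of similar, small size is expected here. From compound 3 to compound 4 the expected step is a number 2.6 percentage points lower from compound 3 to compound 4 (within the scatter). For compound 4 the estimate in this assay is 70%, most likely between 58% and 82%.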

Compound 4, a percentage reported as activity, at one concentration (the size of the read-out at that concentration, not a potency): 90.5%
Estimate against measurement, compound 4: 20.5 percentage points below, and the stated range ends below it.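

In this assay, putting methoxy in place of fluoro gives a number 17.9 percentage points higher from compound 3 to compound 4 (beyond the scatter), so the change did not carry over from the core of compound 1 to the core of compound 3 with the same size or direction: the same change on two cores in this assay, a number 2.4 percentage points lower (within the scatter) from compound 1 to compound 2 and a number 17.9 percentage points higher (beyond the scatter) from compound 3 to compound 4, 20.3 percentage points apart, beyond the scatter of two such steps

In this series, then, the result of this swap on one core cannot be taken as a guide to its result on the other. These two pairs do not show which difference between the cores goes with the gap, how the swap would behave on a third core, or how the compounds would compare at other concentrations, since only a single concentration is reported.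

The compounds shown carry only fluoro or methoxy at this place on the ring. As far as these compounds go, how an amine, a carboxylic acid or a longer chain such as butoxy would read there on either core remains open.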